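The compounds below may be only part of what the source reports. "The series", "measured", "known", "first", "only" and "open" are said of these compounds alone.

Measured so far:
- compound 1, `Clc1ccc(C(Oc2ccc3cc(Br)ccc3c2)c2cnc(NCC3CCCCC3)s2)cc1`: in an ADME assay on HepG2 2.2.15 cells (Homo sapiens) for cytotoxicity (a lower number here means that less compound is tolerated, a higher number that more compound is tolerated), compound 1 is reported as "not toxic" (no number reported)
- compound 2, `Cc1ccc(C)c(S(=O)(=O)Nc2ncc(C(Oc3ccc4cc(Br)ccc4c3)c3ccc(Cl)cc3)s2)c1`: compound 2 gives > 50000 nM

The value of compound 2 in this assay is a limit of the assay, not a number. Compound 1 carries no number either. Going by the values given here, compound 2 therefore stands at the assay ceiling, and no step between two measured compounds that differ in one place is available; nothing on the size of any change has been measured.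

Compound 3, `Cc1ccc(S(=O)(=O)Nc2ncc(C(Oc3ccc4cc(Br)ccc4c3)c3ccc(Cl)cc3)s2)c2ccccc12`, differs from compound 2 by 4-methylnaphthalen-1-yl in place of 2,5-dimethylphenyl on a sulfonyl sulfur. Among the compounds with values here, with no measured step to lean on, the expectation for this change in this assay is no step beyond the scatter, in either direction. Compound 3 is thus expected to sit at 60000 nM, with a range from 25000 nM to 150000 nM. This estimate means a step that the limit leaves unreadable from compound 2 to compound 3, and a reported limit rather than a number is the likelier outcome because of the limit of > 50000 nM in this assay, at which 1 of the 2 values shown sits.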

Compound 3, half-maximal cytotoxic concentration: > 50000 nM
Compound 3: no number, only a limit; the forecaster's own chance of this, stated with the estimate: 80%; the middle value is on the limit's open side.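

In this assay, going by these compounds alone, compound 2 and compound 3 are both reported only as limits of the assay, and no step between them can be read. The compounds shown leave open whether any group on the sulfonyl sulfur changes the tolerated concentration in this assay.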